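The source may hold more compounds than are shown below. What is called first, only, known or untested is meant among the compounds shown, and "the series" means these compounds.

Values in a functional assay on HepG2 cells (Homo sapiens) for antiproliferative activity, read by XTT assay, with a stated time of 72 h; on this read-out lower numbers stand for stronger inhibition and higher numbers for weaker inhibition:

- Compound 1 `COc1ncnc2c1c(-c1ccccc1)cn2[C@@H]1O[C@H](CO)[C@@H](O)[C@H]1O`: > 20000 nM (a limit)
- Compound 2 `C#Cc1cn([C@@H]2O[C@H](CO)[C@@H](O)[C@H]2O)c2ncnc(OC)c12`: 12700 nM
- Compound 3 `CSc1ncnc2c1c(-c1ccsc1)cn2[C@@H]1O[C@H](CO)[C@@H](O)[C@H]1O`: > 15000 nM (a limit)

Compound 1 stands at the limit of > 20000 nM in this assay, at which 1 of the 3 values shown sits, which is a limit and not a number. Compound 4 `CSc1ncnc2c1c(-c1ccccc1)cn2[C@@H]1O[C@H](CO)[C@@H](O)[C@H]1O` differs from it by methylsulfanyl in place of methoxy on an aromatic carbon. Within the data shown here, no measured step makes this exchange. Among the measured compounds shown here, the one measured step, an at least 1.5-fold lower number from compound 1 to compound 2 (0.19 log units; that floor lies within the scatter), replaces phenyl with ethynyl at another place, so it gives no direct size for this change. Compound 3 also carries methylsulfanyl, and it stands at the limit of > 15000 nM in this assay, at which 1 of the 3 values shown sits, again a limit. With compound 1 and compound 3 both reported only as limits, no step beyond the scatter is expected in this assay, and no direction can be assigned. The expected change is a number no higher from compound 1 to compound 4 (the limit leaves the size open). Compound 4 is estimated at 20000 nM, with an expected range of 9000 nM to 40000 nM.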

Compound 4, half-maximal inhibitory concentration: > 20000 nM
Compound 4: only a limit was reported; the forecaster's own chance of this, stated with the estimate: 65%; the middle value sits exactly at the limit.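

In this assay, compound 4 is reported only as a limit, as are compound 1 and compound 3, so the steps to compound 4 from compound 1 and from compound 3 cannot be read. The compounds shown leave open how far methylsulfanyl in place of methoxy, or phenyl in place of thiophen-3-yl, shifts the number.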